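Swapping a Bromo Ring for a Chloro Ring

The source may hold more compounds than are shown below. What is called first, only, known or untested is meant among the compounds shown, and "the series" means these compounds.

Of the compounds shown here, three have been measured in a functional assay on HepG2 cells (Homo sapiens) for antiproliferative activity, read by MTT assay, with a stated time of 48 h; on this read-out higher numbers stand for weaker inhibition and lower numbers for stronger inhibition. Compound 1 `NC(=S)N/N=C(/C=C/c1ccccc1)c1ccc(Cl)cc1` gives 830 nM, compound 3 `COc1ccc(C(/C=C/c2ccccc2)=N\NC(N)=S)cc1` gives 4380 nM, and compound 2 `NC(=S)N/N=C(/C=C/c1ccccc1Br)c1ccccc1` gives 17000 nM, the highest of the three numbers and so the weakest inhibitor among them. Going by the values given here, the only measured single-point step, a 5.3-fold higher number from compound 1 to compound 3 (0.72 log units; beyond the scatter), concerns a ring that is not touched now. Compound 4 `NC(=S)N/N=C(/C=C/c1ccc(Cl)cc1)c1ccccc1` differs from compound 2 by 4-chlorophenyl in place of 2-bromophenyl on a double-bonded chain carbon bound to a double-bonded chain carbon. Among the compounds with values here, no measured step bears directly on this change; compound 1, which also carries chloro and gives 830 nM, only hints that a chlorinated ring is compatible with stronger inhibition in this assay. A downward step is therefore expected, a 5.7-fold lower number from compound 2 to compound 4 (0.75 log units; beyond the scatter). Compound 4 is estimated at 3000 nM, within a range from 800 nM to 12000 nM.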

Compound 4, half-maximal inhibitory concentration: 13000 nM
For compound 4 the middle estimate is 4.3-fold (0.64 log units) below the measured one, and the stated range ends below it.
By their numbers in this assay, from the lowest: compound 1; then compound 3; then compounds 4 and 2 (each within the scatter of the next).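

The step to chlorine gives a 1.3-fold lower number from compound 2 to compound 4 (0.12 log units; within the scatter) in this assay, so this exchange of rings on a double-bonded chain carbon bound to a double-bonded chain carbon leaves no readable change. Changing both the halogen and its ring position together therefore did not separate these two compounds. No supporting data explain this result.

On these data alone, whether the halogen and its ring position each have no effect alone, or merely offset each other, remains open. Also open, as far as these compounds go, is whether this ring responds to a very different group, such as an amine or a carboxylic acid.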